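A few compounds are considered here, and "the series" means these few. Any claim that something is new, unique, unknown or untested is made for them only; others in the source may bear on it.

Measured in a functional assay on A-431 cells (Homo sapiens) for antiproliferative activity, read by CCK-8 assay, with a stated time of 48 h; on this read-out higher numbers stand for weaker inhibition and lower numbers for stronger inhibition:
compound 1, `COc1ccc(Nc2nc(Nc3cc(C)[nH]n3)cc(N3CCN(C)CC3)n2)cc1OC`: 778 nM
compound 2, `Cc1cc(Nc2cc(N3CCN(C)CC3)nc(Nc3ccc(Cl)c(F)c3)n2)n[nH]1`: 136 nM
compound 3, `Cc1cc(Nc2cc(N3CCN(C)CC3)nc(Nc3ccc(Cl)c(Cl)c3)n2)n[nH]1`: 129 nM

Compound 3 carries the lowest of the three numbers, but its separation from compound 2, a 1.1-fold lower number from compound 2 to compound 3 (0.02 log units; within the scatter), lies within the scatter, so the two cannot be ranked against each other; compound 1 stands furthest away, the gap being a 6.0-fold lower number from compound 1 to compound 3 (0.78 log units; beyond the scatter). Both a 5.7-fold lower number from compound 1 to compound 2 (0.76 log units; beyond the scatter) and a 6.0-fold lower number from compound 1 to compound 3 (0.78 log units; beyond the scatter) show the 4-chloro-3-fluorophenyl and 3,4-dichlorophenyl groups giving lower numbers than 3,4-dimethoxyphenyl, while chloro against fluoro at the one varied position made no separable difference.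

Compound 4, `Cc1cc(Nc2cc(N3CCN(C)CC3)nc(Nc3ccc(F)c(F)c3)n2)n[nH]1`, is not yet measured in this assay. It differs from compound 3 in one place: 3,4-difluorophenyl in place of 3,4-dichlorophenyl on a nitrogen on an aromatic ring. Within the data shown here, the only measured step that bears on this is the single chloro-to-fluoro exchange, a 1.1-fold lower number from compound 2 to compound 3 (0.02 log units; within the scatter), which stayed within the scatter. Here the exchange is made at both halogen positions at once, and no measured pair covers that directly. The expectation is that compound 4 stays close to compound 3, with the step of a 1.3-fold higher number from compound 3 to compound 4 (0.12 log units; within the scatter) expected to remain within the scatter or amount to no more than a small rise. Compound 4 is estimated at 170 nM in this assay, within 80 nM to 400 nM.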

Compound 4, half-maximal inhibitory concentration: 177 nM
Estimate against measurement, compound 4: 1.0-fold (0.02 log units) below; the measured number falls inside the stated range.
By their numbers in this assay, from the lowest: compounds 3, 2 and 4 (each within the scatter of the next); then compound 1.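

In this assay, among these compounds, fluoro in place of both chloro groups gives a 1.4-fold higher number from compound 3 to compound 4 (0.14 log units; within the scatter), and the single exchange that turns the 4-chloro-3-fluorophenyl group into 3,4-difluorophenyl gives a 1.3-fold higher number from compound 2 to compound 4 (0.11 log units; within the scatter). Among the compounds shown here, the earlier compounds covered only one halogen exchange, whereas these steps show that exchanging both halogens also leaves the number within the scatter, so compound 2, compound 3 and compound 4 cannot be ranked against one another. The third halogenated group also stands apart from 3,4-dimethoxyphenyl, with a 4.4-fold lower number from compound 1 to compound 4 (0.64 log units; beyond the scatter), so all three halogenated compounds now have numbers beyond the scatter from compound 1. No measurement at hand offers an explanation for these steps.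

The compounds shown leave open whether this insensitivity extends to bromo or methyl groups, or whether an unsubstituted phenyl would give a number like those of the halogenated compounds or like that of compound 1. They also leave open how a single methoxy group, or one chloro paired with one methoxy, would compare, which would show whether the gap to compound 1 depends on one substituent or on both.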